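A triazole in place of methoxy on a shared core

The source may report more compounds than this note shows. Statements on the series, on what has been measured and on what is new or still open speak of the compounds shown alone.

In a functional assay on A549 cells (Homo sapiens) for antiproliferative activity, read by MTT assay, with a stated time of 48 h (a higher number here means a weaker inhibitor, a lower number a stronger inhibitor), compound 1 `COC/C1=C/C[C@](C)(CCC=C(C)C)/C=C/[C@@H](OC(=O)C=C(C)C)[C@](C)(O)/C=C/C1=O` gives 3950 nM, the higher of the two plain numbers available. Compound 3 `CC(C)=CCC[C@]1(C)/C=C/[C@@H](OC(=O)C=C(C)C)[C@](C)(O)/C=C/C(=O)/C(CN(C(C)C)C(C)C)=C\C1` gives 650 nM, and the step between them is a 6.1-fold lower number from compound 1 to compound 3 (0.78 log units; beyond the scatter). Compound 2 `CC(C)=CCC[C@]1(C)/C=C/[C@@H](OC(=O)C=C(C)C)[C@](C)(O)/C=C/C(=O)/C(C(=O)O)=C\C1` reaches only the limit > 10000 nM, a ceiling of the assay rather than a measured number (the limit of > 10000 nM in this assay, at which 1 of the 3 values shown sits). The steps of an at least 2.5-fold higher number from compound 1 to compound 2 (0.40 log units; beyond the scatter) and an at least 15-fold lower number from compound 2 to compound 3 (1.18 log units; beyond the scatter) alter the group on the ring carbon itself and so bear less directly on the present question. Compound 4 `CC(C)=CCC[C@]1(C)/C=C/[C@@H](OC(=O)C=C(C)C)[C@](C)(O)/C=C/C(=O)/C(Cn2cc(CO)nn2)=C\C1` differs from compound 1 by 4-(hydroxymethyl)-1H-1,2,3-triazol-1-yl in place of methoxy on a saturated chain carbon bound to a double-bonded ring carbon. Going by the values given here, only the step from compound 1 to compound 3 touches the same place, and there an amine entered; a neutral aromatic ring carrying a hydroxymethyl group is a different kind of replacement, so its direction cannot be read from that step alone. Compound 4 is therefore expected to show a 1.3-fold lower number from compound 1 to compound 4 (0.12 log units; within the scatter), a change within the scatter or a modest lowering. The estimate for compound 4 is 3000 nM, ranging from 1000 nM to 9000 nM.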

Compound 4, half-maximal inhibitory concentration: 3470 nM
Compound 4: the middle estimate sits 1.2-fold (0.06 log units) below what was measured; the measured number falls inside the stated range.
By their numbers in this assay, from the lowest: compound 3; then compounds 4 and 1 (each within the scatter of the next). At a limit, above all of these: compound 2.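

Replacing methoxy with the far larger 4-(hydroxymethyl)-1H-1,2,3-triazol-1-yl on this saturated chain carbon leaves the number essentially unmoved (a 1.1-fold lower number from compound 1 to compound 4 (0.06 log units; within the scatter)), so this position tolerates an aromatic ring carrying a hydrogen-bond donor. The lower number seen with diisopropylamino does not carry over to this replacement (a 5.3-fold higher number from compound 3 to compound 4 (0.73 log units; beyond the scatter)), so a new group at this place does not by itself lower the number. The remaining step (an at least 2.8-fold lower number from compound 2 to compound 4 (0.45 log units; beyond the scatter)) starts from a limit of the assay and is therefore only a bound: the limit of > 10000 nM in this assay, at which 1 of the 4 values shown sits.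

On these data alone, whether the lower number of compound 3 belongs to amines generally stays open, and a smaller amine such as dimethylamino or a cyclic one such as morpholine on the same carbon would test that. Also open, as far as these compounds go, is whether the hydroxymethyl matters, which a triazole bearing a plain methyl or phenyl group would address.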